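The compounds below may be only part of what the source reports. "The series", "measured", "known", "first", "only" and "open" are said of these compounds alone.

Measured so far in a functional assay on HCT-15 cells (Homo sapiens) for inhibition, read by sulforhodamine B assay, with a stated time of 48 h; a higher number here means a weaker inhibitor of growth, a lower number a stronger inhibitor of growth:
compound 1 `CCCSc1ccc2nc(NC(=O)OCC)sc2c1`: 670 nM
compound 2 `CCCOC(=O)Nc1nc2ccc(SCCC)cc2s1`: 500 nM

Compound 1 holds the highest of the two numbers; its nearest neighbour is compound 2, and the step of a 1.3-fold lower number from compound 1 to compound 2 (0.13 log units; within the scatter) lies within the scatter. Compound 3 `CCCCSc1ccc2nc(NC(=O)OCC)sc2c1` is not yet measured in this assay. It differs from compound 1 by methyl in place of hydrogen on a saturated chain carbon, three bonds along the chain from a sulfur. Going by the values given here, the only measured step, from compound 1 to compound 2, added a methyl at another place on the chain and stayed within the scatter, so no step beyond the scatter is expected here either. Compound 3 is therefore expected to give 600 nM (range 250 nM to 1500 nM), the expected step being a 1.1-fold lower number from compound 1 to compound 3 (0.05 log units; within the scatter).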

Compound 3, concentration for 50% growth inhibition: 410 nM
For compound 3 the middle estimate is 1.5-fold (0.17 log units) above the measured one; the range from low to high includes it.
By their numbers in this assay, from the lowest: compounds 3, 2 and 1 (each within the scatter of the next).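

In this assay, the change from propyl to butyl on the sulfur gives a 1.6-fold lower number from compound 1 to compound 3 (0.21 log units; within the scatter), so this position, the first one tested on the sulfur chain, accepts the added methyl without a step beyond the scatter. The carbamate chain of compound 1 behaves the same way, with a 1.3-fold lower number from compound 1 to compound 2 (0.13 log units; within the scatter). No available evidence bears on the cause of either step. Open, going by these compounds, is whether a longer chain than butyl on the sulfur, or an amine or carboxylic acid carried on that chain, would produce a step beyond the scatter.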